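Swapping a Nitrophenyl for Cycloheptyl on a Piperazine-Bearing Core

This account rests on a few compounds, and the source may have more. Where it says the series, first, only, none or still open, it means among the compounds named here.

Measured so far:
- Compound 1 `Nc1scc(CN2CCN(c3ccc([N+](=O)[O-])cc3)CC2)c1C(=O)c1ccc(Cl)cc1`: 1%
- Compound 2 `Nc1scc(CN2CCN(c3cccc(F)c3)CC2)c1C(=O)c1cccc(C(F)(F)F)c1`: 0%
- Compound 3 `Nc1scc(CN2CCN(c3c(F)cccc3F)CC2)c1C(=O)c1cccc(C(F)(F)F)c1`: 0%

All three compounds share a core and were tested in an assay on CHO cells for displacement of a labelled ligand from adenosine receptor A1 (Homo sapiens), read by scintillation counting, with a stated time of 120 min, tested at 10 uM; on this read-out higher numbers stand for more inhibition at the one concentration tested (going by the name of the read-out) and lower numbers for less inhibition. Compound 1 gives the highest of the three numbers, yet its gap to compound 2 and to compound 3 lies within the scatter, so no order among them can be claimed; all three sit at the bottom of the scale, essentially without measurable inhibition.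

Among the compounds with values here, the only step that can be read directly, from compound 2 to compound 3, replaces the group on the ring nitrogen of the six-membered ring with two nitrogens: no change at the digits printed from compound 2 to compound 3 (within the scatter). That change left the read-out flat.

Compound 4 `Nc1scc(CN2CCN(C3CCCCCC3)CC2)c1C(=O)c1ccc(Cl)cc1` differs from compound 1 at the same ring nitrogen: cycloheptyl in place of 4-nitrophenyl on an amine nitrogen in a ring. Within the data shown here, no measured step swaps an aromatic group for a saturated ring at this place, so the one step that bears on it is only loosely related. Since the shown change at that nitrogen produced no movement, and since compound 1 starts at 1%, a step near zero is expected, a number 2 percentage points higher from compound 1 to compound 4 (within the scatter). For compound 4 the expected value is 3%, estimated between -8% and 15%.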

Compound 4, a percentage reported as inhibition, at one concentration (the size of the read-out at that concentration, not a potency): 0%
Compound 4: middle estimate off by 3 percentage points, on the high side; low and high end bracket the measured number.
By their numbers in this assay, from the lowest: compounds 2, 3, 4 and 1 (each within the scatter of the next).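

In this assay, putting cycloheptyl in place of 4-nitrophenyl on the amine nitrogen gives a number 1 percentage points lower from compound 1 to compound 4 (within the scatter), so a change far larger than moving fluorine atoms around an aromatic ring also leaves the read-out flat. The exchange replaces a six-membered aromatic ring with a seven-membered non-aromatic ring and gives up the 2 hydrogen-bond acceptors of 4-nitrophenyl, yet neither difference can be told from the scatter, and both aromatic and non-aromatic groups at this position now sit at the bottom of the scale. No separate measurement is available to explain this flat result.

Since every compound shown sits so close to the bottom of the scale, these results cannot show how much the group on this nitrogen matters, as a change that weakens inhibition would be hard to see. From the compounds shown here alone, it remains open whether a benzyl group, a longer chain such as n-butyl, or a chain ending in a carboxylic acid at this nitrogen would give a clearly higher number in this assay.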